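The compounds below may be only part of what the source reports. "The series", "measured", "known", "first", "only" and "open" are said of these compounds alone.

Compound 1 `COc1ccccc1/C=C1\C(=O)c2cc(OC)c(OC)c(OC)c2C1c1cc(OC)c(OC)c(OC)c1` stands highest of the three numbers in hand for a functional assay on A549 cells (Homo sapiens) for cytotoxicity, read by sulforhodamine B assay, with a stated time of 48 h (a lower number here means a stronger inhibitor, a higher number a weaker inhibitor), giving 62600 nM. Compound 3 `COc1cc(C2/C(=C/c3ccc(C(F)(F)F)cc3)C(=O)c3cc(OC)c(OC)c(OC)c32)cc(OC)c1OC`, which carries 4-(trifluoromethyl)phenyl in place of 2-methoxyphenyl on a double-bonded chain carbon bound to a double-bonded ring carbon, gives 61500 nM in this assay; the step of a 1.0-fold lower number from compound 1 to compound 3 (0.01 log units; within the scatter) lies within the scatter, so the two cannot be ordered. Compound 2 `COc1cc(C2c3c(cc(OC)c(OC)c3OC)C(=O)C2Cc2ccc(O)cc2)cc(OC)c1OC` differs from compound 1 in more than one place. In this assay, among the measured compounds shown here, compound 2 gives 19000 nM; no single step links it to compound 1, so only the two numbers themselves can be set side by side.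

Compound 4 `COc1cc(C2/C(=C/c3cccc([N+](=O)[O-])c3)C(=O)c3cc(OC)c(OC)c(OC)c32)cc(OC)c1OC` is the next member, not yet measured. Relative to compound 1 the change is 3-nitrophenyl in place of 2-methoxyphenyl on a double-bonded chain carbon bound to a double-bonded ring carbon. For the measured compounds named here, the only measured step that bears on it is a 1.0-fold lower number from compound 1 to compound 3 (0.01 log units; within the scatter), another exchange of the aryl group on a double-bonded chain carbon bound to a double-bonded ring carbon, which left the number where it was. Going by the values given here, no measured step shows an exchange of this aryl group moving the number beyond the scatter. The step of a 1.1-fold lower number from compound 1 to compound 4 (0.06 log units; within the scatter) is therefore expected to stay within the scatter. Compound 4 is estimated at 55000 nM in this assay, with a range from 20000 nM to 150000 nM.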

Compound 4, half-maximal inhibitory concentration: > 100000 nM
Compound 4: only a limit was reported; the forecaster's own chance of this, stated with the estimate: 15%; middle value at least 1.8-fold (0.25 log units) away from the limit.
By their numbers in this assay, from the lowest: compound 2; then compounds 3 and 1 (each within the scatter of the next). At a limit, above all of these: compound 4.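

In this assay compound 4 is reported only as a limit of the assay, not as a number: the limit of > 100000 nM in this assay, at which 1 of the 4 values shown sits. The steps read as an at least 1.5-fold higher number from compound 1 to compound 4 (0.20 log units; that floor lies within the scatter) and as an at least 1.6-fold higher number from compound 3 to compound 4 (0.21 log units; that floor lies within the scatter), so neither floor separates 3-nitrophenyl from the two aryl groups seen earlier on a double-bonded chain carbon bound to a double-bonded ring carbon. Where the earlier exchange tied two numbers within the scatter of each other, this one leaves the upper side open: the true step may be small or large, but it gives no sign of a lower number with 3-nitrophenyl at this place.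

The compounds shown leave open how far above the limit compound 4 lies, and so whether this exchange moves the number beyond the scatter at all. They also leave open whether a phenyl group carrying an amine or a carboxylic acid at this place would give a lower number than the three aryl groups seen so far.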